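Capping a ring amine: a sulfonyl in place of an acyl

A few compounds are considered here, and "the series" means these few. Any claim that something is new, unique, unknown or untested is made for them only; others in the source may bear on it.

Measured compounds:
Compound 1 `CCN(CC)c1ccc2cc(C(=O)c3ccc(N4CCN(C(=O)CN5CCNCC5)CC4)cc3)oc2c1` gives 1350 nM in a functional assay on HeLa cells (Homo sapiens) for cytotoxicity, read by MTT assay, with a stated time of 48 h; on this read-out higher numbers stand for weaker inhibition and lower numbers for stronger inhibition.
Compound 2 `CCN(CC)c1ccc2cc(C(=O)c3ccc(N4CCN(C(=O)CN5CCN(C(=O)CCl)CC5)CC4)cc3)oc2c1` gives 5520 nM in this assay.
Compound 3 `CCN(CC)c1ccc2cc(C(=O)c3ccc(N4CCN(C(=O)CN5CCN(C(=O)/C=C/c6ccccc6)CC5)CC4)cc3)oc2c1` gives 5260 nM in this assay.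

Compound 3 stands second highest of the three numbers; its nearest neighbour is compound 2, the two lying within the scatter of each other, while compound 1 sits well below both. The step from compound 3 to compound 4 `CCN(CC)c1ccc2cc(C(=O)c3ccc(N4CCN(C(=O)CN5CCN(S(=O)(=O)C6CC6)CC5)CC4)cc3)oc2c1` is cyclopropylsulfonyl in place of (2-phenylethenyl)carbonyl on an amine nitrogen in a ring. Among the measured compounds shown here, three measured steps bear on it. The steps of a 4.1-fold higher number from compound 1 to compound 2 (0.61 log units; beyond the scatter) and a 3.9-fold higher number from compound 1 to compound 3 (0.59 log units; beyond the scatter) show that placing either of two quite different groups on this ring nitrogen raised the number by a modest and nearly equal amount. The step of a 1.0-fold lower number from compound 2 to compound 3 (0.02 log units; within the scatter) shows that exchanging one such group for the other changed nothing beyond the scatter. Compound 4 keeps the ring nitrogen substituted, so its number is expected to stay near those of compound 2 and compound 3. The resulting step is expected to be a 1.1-fold lower number from compound 3 to compound 4 (0.02 log units; within the scatter), within the scatter. For compound 4 the estimate in this assay is 5000 nM, with a range from 2500 nM to 10000 nM.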

Compound 4, half-maximal inhibitory concentration: 28100 nM
Estimate against measurement, compound 4: 5.6-fold (0.75 log units) below; measured number outside the range, above it.
By their numbers in this assay, from the lowest: compound 1; then compounds 3 and 2 (each within the scatter of the next); then compound 4.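

In this assay, the nature of the group on this ring nitrogen turns out to matter: cyclopropylsulfonyl gives a 5.3-fold higher number from compound 3 to compound 4 (0.73 log units; beyond the scatter) and a 5.1-fold higher number from compound 2 to compound 4 (0.71 log units; beyond the scatter), so the flat picture from the two carbonyl-linked groups of compound 2 and compound 3 does not extend to this sulfonyl group. Measured against the free ring amine, the same group gives a 21-fold higher number from compound 1 to compound 4 (1.32 log units; beyond the scatter), and all three substituents on this nitrogen give higher numbers than hydrogen, with no compound shown going against that pattern. The size of that rise therefore depends on the group: it is modest for compound 2 and compound 3 but large for compound 4.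

Nothing shown gives a measured reason for the rise at compound 4. Since the change replaces both the carbonyl link and the group it carries, the compounds shown leave open whether the sulfonyl or the cyclopropyl accounts for the step, a question that a cyclopropylcarbonyl group or a phenylsulfonyl group on the same nitrogen would address.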